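Aryl ether back in place of cyanobenzyl: expected dissociation

A few compounds are considered here, and "the series" means these few. Any claim that something is new, unique, unknown or untested is made for them only; others in the source may bear on it.

Compound 3 `COc1cccc(CNCCCNc2ccnc3cc(Cc4ccc(C#N)cc4)ccc23)c1O` gives 9.47 in a physicochemical assay for acid dissociation, the highest of the three numbers measured, although its steps to compound 1 `COc1cccc(Oc2ccc3c(NCCCNCc4cccc(OC)c4O)ccnc3c2)c1` and compound 2 `COc1cccc(CNCCCNc2ccnc3cc(Oc4ccccc4)ccc23)c1O` both lie within the scatter. In this assay compound 1 gives 9.28 and compound 2 gives 9.28. The change to compound 4 `COc1cccc(CNCCCNc2ccnc3cc(Oc4cccc(N(C)C)c4)ccc23)c1O` is 3-(dimethylamino)phenoxy in place of 4-cyanobenzyl on an aromatic carbon. Going by the values given here, the steps that bear on it run the opposite way: a number 0.19 log units higher from compound 2 to compound 3 (within the scatter) and a number 0.19 log units higher from compound 1 to compound 3 (within the scatter), each within the scatter. Putting an aryl ether back where the 4-cyanobenzyl stood should therefore move the number little, if at all, in this assay. Compound 4 is expected at 9.3, between 9 and 9.6. The expected step is a number 0.17 log units lower from compound 3 to compound 4 (within the scatter), which stays within the scatter.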

Compound 4, acid dissociation constant: 9.28
Compound 4: middle estimate off by 0.02 log units, on the high side; low and high end bracket the measured number.
By their numbers in this assay, from the lowest: compounds 1, 2, 4 and 3 (each within the scatter of the next).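

In this assay this position on the shared core accepts an aryl ether carrying dimethylamino with no step beyond the scatter: 3-(dimethylamino)phenoxy in place of 4-cyanobenzyl gives (a number 0.19 log units lower from compound 3 to compound 4 (within the scatter)). On the phenoxy group, dimethylamino in place of hydrogen gives (no change at the digits printed from compound 2 to compound 4 (within the scatter)) and dimethylamino in place of methoxy gives (no change at the digits printed from compound 1 to compound 4 (within the scatter)), so all three aryl ethers print one number. No measurement at hand offers an explanation for this. On these data alone, whether a carboxylic acid on the phenoxy group, or a longer chain at this position, would leave the number within the scatter remains open.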